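A few compounds are considered here, and "the series" means these few. Any claim that something is new, unique, unknown or untested is made for them only; others in the source may bear on it.

Compound 1 `CS(=O)(=O)c1ccc2nc(NC(=O)CCCCC(=O)NO)sc2c1` belongs to a small set of hydroxamic acids built on a shared core. In a functional assay on MCF7 cells (Homo sapiens) for cytotoxicity (on this read-out higher numbers stand for weaker inhibition and lower numbers for stronger inhibition), compound 1 gives only a limit, > 30 ug/mL, and not a number. On the numbers shown, compound 1 therefore sits at the limit of > 30 ug/mL in this assay, at which 1 of the 2 values shown sits. Compound 2 `COc1ccc2nc(NC(=O)CCCCCCC(=O)NO)sc2c1` carries a methoxy group and a longer chain, and in this assay compound 2 gives 1.85 ug/mL. Compound 3 `O=C(CCCCC(=O)Nc1nc2ccccc2s1)NO` has not yet been measured; it differs from compound 1 by hydrogen in place of methylsulfonyl on an aromatic carbon. He expects the step of an at least 3.7-fold lower number from compound 1 to compound 3 (0.57 log units; beyond the scatter) to run toward stronger inhibition, beyond the scatter. For compound 3 he estimates 8 ug/mL, within 2 ug/mL to 30 ug/mL.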

Compound 3, half-maximal inhibitory concentration: 4.02 ug/mL
For compound 3 the middle estimate is 2.0-fold (0.30 log units) above the measured one; measured number inside the range.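

In this assay, among these compounds, hydrogen in place of methylsulfonyl on this aromatic carbon gives an at least 7.4-fold lower number from compound 1 to compound 3 (0.87 log units; beyond the scatter) and so the first step at this position that can be read. Compound 3 shows that the shared core with this chain needs no substituent here to give a measured number. The step is only a bound, as the value of compound 1 is a limit of the assay: the limit of > 30 ug/mL in this assay, at which 1 of the 3 values shown sits.

The compounds shown leave open how an amine or a carboxylic acid on this carbon would read. They also leave open what a longer chain alone would do on compound 3.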